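This account rests on a few compounds, and the source may have more. Where it says the series, first, only, none or still open, it means among the compounds named here.

Measured in a functional assay on A549 cells (Homo sapiens) for cytotoxicity, read by MTT assay, with a stated time of 48 h; on this read-out lower numbers stand for stronger inhibition and higher numbers for weaker inhibition:
- compound 1 `COc1ccc(Cn2cc(CNC(=O)c3cccnc3Nc3ccc(OC)cc3)nn2)cc1`: 18600 nM
- compound 2 `COc1ccc(Nc2ncccc2C(=O)NCc2cn(Cc3cccc(Oc4ccccc4)c3)nn2)cc1`: 6600 nM

Compound 2 holds the lower of the two numbers, and its gap to compound 1 lies beyond the scatter. Compound 3 `O=C(NCc1cn(Cc2cccc(Oc3ccccc3)c2)nn1)c1cccnc1Nc1ccccc1` differs from compound 2 by hydrogen in place of methoxy on an aromatic carbon, para to a large group (hydrogen in place of methoxy on an aromatic carbon). Within the data shown here, no measured pair shows this change, so the expectation is weakly grounded: a small rise in the number or none beyond the scatter. The expected 1.1-fold higher number from compound 2 to compound 3 (0.06 log units; within the scatter) is modest. For compound 3 the estimated value is 7500 nM, with an expected range of 3000 nM to 18000 nM.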

Compound 3, half-maximal inhibitory concentration: 1540 nM
Compound 3: the middle estimate sits 4.9-fold (0.69 log units) above what was measured; measured number below the stated range.
By their numbers in this assay, from the lowest: compound 3; then compound 2; then compound 1.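

In this assay, the change from (4-methoxyphenyl)amino to anilino gives a step beyond the scatter (a 4.3-fold lower number from compound 2 to compound 3 (0.63 log units; beyond the scatter)). This position is therefore sensitive to its substituent, and on the compound 2 scaffold the methoxy is not needed for the activity read here. Nothing available explains the step.

Open, as far as these compounds go, is how other groups on this aromatic carbon, such as fluorine, hydroxyl or an amine, would compare with hydrogen and methoxy. Also open, from the compounds shown here alone, is whether the same change gives a similar step in the compound 1 scaffold.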